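This account rests on a few compounds, and the source may have more. Where it says the series, first, only, none or still open, it means among the compounds named here.

Working notes on the series.

Compound 3 `COc1ccc(CN(C(C)=O)c2cc(OC)c(OC)c(OC)c2)cc1O` carries an acetyl group on the amide nitrogen of the shared core. In a functional assay on HCT-116 cells (Homo sapiens) for inhibition, read by MTT assay, with a stated time of 48 h (a lower number here means a stronger inhibitor, a higher number a weaker inhibitor), compound 3 gives 270 nM, the highest number among the three compounds measured. Its nearest neighbour is compound 2 `COc1ccc(CN(C(=O)CCCl)c2cc(OC)c(OC)c(OC)c2)cc1O`, which gives 150 nM; the step of a 1.8-fold higher number from compound 2 to compound 3 (0.26 log units; within the scatter) lies within the scatter. The furthest is compound 1 `COc1ccc(CN(C(=O)C2CC2)c2cc(OC)c(OC)c(OC)c2)cc1O`, which gives 49 nM; the step of a 5.5-fold higher number from compound 1 to compound 3 (0.74 log units; beyond the scatter) is beyond the scatter, as is a 3.1-fold higher number from compound 1 to compound 2 (0.49 log units; beyond the scatter).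

Compound 4 `C=C(C)C(=O)N(Cc1ccc(OC)c(O)c1)c1cc(OC)c(OC)c(OC)c1` is not yet measured. It differs from compound 3 as follows: 1-methylethenyl in place of methyl on a carbonyl carbon.

The step that bears most directly on this change is a 5.5-fold higher number from compound 1 to compound 3 (0.74 log units; beyond the scatter), where a three-carbon group on the carbonyl carbon went with a markedly lower number than methyl. The step of a 1.8-fold higher number from compound 2 to compound 3 (0.26 log units; within the scatter) adds little, lying within the scatter. On this basis a lower number is expected for compound 4, with the size uncertain since the entering group is not cyclopropyl.

Compound 4 is estimated to give 100 nM, with a range from 40 nM to 250 nM. The expected step is a 2.7-fold lower number from compound 3 to compound 4 (0.43 log units; beyond the scatter), a modest gain anchored to compound 1 and its value 49 nM.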

Compound 4, half-maximal inhibitory concentration: 200 nM
Estimate against measurement, compound 4: 2.0-fold (0.30 log units) below, and the stated range covers the measured number.
By their numbers in this assay, from the lowest: compound 1; then compounds 2, 4 and 3 (each within the scatter of the next).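

In this assay, putting 1-methylethenyl on the carbonyl carbon in place of methyl gives no separation beyond the scatter (a 1.4-fold lower number from compound 3 to compound 4 (0.13 log units; within the scatter)), and the same holds against 2-chloroethyl (a 1.3-fold higher number from compound 2 to compound 4 (0.12 log units; within the scatter)), so compounds 2, 3 and 4 form one group despite their different acyl substituents. Cyclopropyl alone stands apart among the groups shown (a 4.1-fold higher number from compound 1 to compound 4 (0.61 log units; beyond the scatter)), which means that the low number of compound 1 does not carry over to the open-chain 1-methylethenyl group, with its double bond and no ring, and that the earlier comparison with methyl alone could not reveal this. Nothing available on the compounds accounts for this difference between cyclopropyl and the other groups.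

The compounds shown leave open whether the advantage of compound 1 belongs to the ring itself or to cyclopropyl specifically, a question that isopropyl, cyclobutyl or phenyl on the same carbonyl carbon would address. They also leave open how this position responds to an amine, a carboxylic acid or a longer chain.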